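A few compounds are considered here, and "the series" means these few. Any claim that something is new, unique, unknown or untested is made for them only; others in the source may bear on it.

Measured compounds:

Compound 1, `Cc1cccc(Oc2ccnc(N3CCC[C@H]3C(=O)NCc3cccnc3)n2)c1`, gives 4%.
Compound 2, `Clc1ccc2sc(CN3CCN(c4ncnc5c4CN(Cc4ccccc4)CC5)CC3)cc2c1`, gives 0%.

Both values come from an assay on isolated protein for inhibition of serine/threonine-protein kinase Chk2 (Homo sapiens), read by HTRF, tested at 10 uM; a higher number here means more inhibition at the concentration tested (going by the name of the read-out), a lower number less inhibition. Among the measured compounds shown here, compound 1 and compound 2 are built on different frameworks, and no pair among the measured compounds differs in a single place, so no measured step is available. Compound 2 and compound 1 lie within the usual scatter of each other, so the two cannot be told apart on these numbers; both show essentially no inhibition at the concentration tested.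

Compound 3, `O=C(CN1CCN(c2ncnc3c2CN(Cc2ccccc2)CC3)CC1)Nc1cc(F)ccc1F`, shares the core of compound 2 and has not yet been measured. It differs from compound 2 in one place: (2,5-difluorophenyl)carbamoyl in place of 5-chloro-1-benzothiophen-2-yl on a saturated chain carbon bound to an amine nitrogen in a ring.

For the measured compounds named here, with no measured step to go by and both measured compounds near zero in this assay, the expectation for compound 3 is a step of a number 5 percentage points higher from compound 2 to compound 3 (within the scatter), that is, none beyond the scatter. Compound 3 is therefore estimated at 5%, with a range from -5% to 20%.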

Compound 3, a percentage reported as inhibition, at one concentration (the size of the read-out at that concentration, not a potency): 5%
The estimate for compound 3 equals the measured number at the digits printed; measured number inside the range.
By their numbers in this assay, from the lowest: compounds 2, 1 and 3 (each within the scatter of the next).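

Among the compounds shown here, this is the first single-place step in the set, and in this assay it is a step of a number 5 percentage points higher from compound 2 to compound 3 (within the scatter). On the shared core, a 5-chloro-1-benzothiophen-2-yl group and a (2,5-difluorophenyl)carbamoyl group on this saturated chain carbon therefore cannot be told apart, even though the change removes the sulfur and chlorine, replaces two aromatic rings with one, and adds an amide with its hydrogen-bond donor. Neither group brings clear inhibition at the concentration tested, and no available measurement accounts for this result.

Because both values sit near zero, this single step cannot show whether the position matters for inhibition, since a change that made the compounds slightly weaker would be hard to detect here. Going by these compounds, what a primary amine, a carboxylic acid or a longer chain at the same place would do to the read-out remains open, as does whether any change on this core can lift inhibition clearly above the scatter.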